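This account rests on a few compounds, and the source may have more. Where it says the series, first, only, none or still open, it means among the compounds named here.

Among the measured compounds shown here, in an ADME assay on brain (Rattus norvegicus) for protein binding, read by LC-MS, using equilibrium dialysis, with a stated time of 6 h (a higher number here means a larger unbound share of the compound, a lower number a smaller unbound share), compound 1 `CCCOc1ccc(C(=O)Nc2cc(OC(F)(F)F)ccc2-n2cncn2)cc1OC` gives 0.009 and compound 2 `COc1cc(C(=O)Nc2cc(OC(F)(F)F)ccc2-n2cncn2)ccc1OC(C)C` gives 0.013 within the scatter of it, so compound 2 stands level with compound 1 on the numbers so far. Compound 3 `COc1cc(C(=O)Nc2cc(OC(F)(F)F)ccc2-n2cncn2)ccc1OC1CC1` keeps the core of compound 2 and carries the change cyclopropyl in place of isopropyl on an oxygen on an aromatic ring on the oxygen, isopropoxy to cyclopropyloxy. For the measured compounds named here, the only measured step on this oxygen, isopropyl in place of propyl, is a 1.4-fold higher number from compound 1 to compound 2 (0.16 log units; within the scatter) and it gives no ground to expect more than scatter in this assay here, although no three-membered ring on this oxygen has yet been measured. No direction is supported, so no change at the digits printed from compound 2 to compound 3 (within the scatter) is the step expected. Compound 3 is estimated at 0.013 with an expected range from 0.007 to 0.024 for this measurement.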

Compound 3, unbound fraction: 0.013
Compound 3: middle estimate and measured number agree at the digits printed, within the range that was stated.
By their numbers in this assay, from the lowest: compounds 1, 2 and 3 (each within the scatter of the next).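

In this assay the change from isopropoxy to cyclopropyloxy gives no change at the digits printed from compound 2 to compound 3 (within the scatter), and the comparison with the propyl group gives a 1.4-fold higher number from compound 1 to compound 3 (0.16 log units; within the scatter), so a three-membered ring on this oxygen has now been measured and stands level with both open chains. Propyl, isopropyl and cyclopropyl, each of three carbons, therefore do not separate in this read-out, whether the carbons form a straight chain, a branched chain or a ring. Nothing available explains why these three groups read alike.

The compounds shown leave open whether a longer chain, an amine or a carboxylic acid on this oxygen would shift the unbound fraction beyond the scatter. They also leave open whether changes elsewhere on the shared core would do so.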